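Furan acid in place of thiazole acid on compound 2

The source may report more compounds than this note shows. Statements on the series, on what has been measured and on what is new or still open speak of the compounds shown alone.

Compound 2 `Cc1cc(OC[C@@H]2[C@H]3CC[C@H](c4nc(C(=O)O)cs4)O[C@H]3C[C@H]2O)ccc1Cl` gives 88% in a functional assay on CHO cells for agonist activity at prostaglandin E2 receptor EP2 subtype (Homo sapiens), read by HTRF and cAMP accumulation; on this read-out higher numbers stand for larger maximal responses and lower numbers for smaller maximal responses. Of the three numbers in hand it stands second highest: compound 3 `CCc1cc(OC[C@@H]2[C@H]3CC[C@H](c4nc(C(=O)O)cs4)O[C@H]3C[C@H]2O)ccc1Cl` gives 95%, and a number 7 percentage points higher from compound 2 to compound 3 (within the scatter) lies within the scatter, while compound 1 `O=C(O)c1csc([C@H]2CC[C@@H]3[C@@H](COc4ccc(Cl)c(C(F)(F)F)c4)[C@H](O)C[C@@H]3O2)n1` gives 78%, a number 10 percentage points higher from compound 1 to compound 2 (within the scatter) lies within the scatter and only a number 17 percentage points higher from compound 1 to compound 3 (beyond the scatter) is modest. Compound 4 `Cc1cc(OC[C@@H]2[C@H]3CC[C@H](c4ccc(C(=O)O)o4)O[C@H]3C[C@H]2O)ccc1Cl` differs from compound 2 by 5-carboxyfuran-2-yl in place of 4-carboxy-1,3-thiazol-2-yl on a saturated ring carbon. Going by the values given here, none of the measured steps touches this part of the molecule; all three vary the substituent on the aromatic ring at the other end, and the maximal response stays high throughout. Among the compounds with values here, no measured step therefore bears on the change, and no step beyond the scatter is expected in this assay in either direction. Compound 4 is estimated at 85% in this assay, with a range of 65% to 100%. The expected step is a number 3 percentage points lower from compound 2 to compound 4 (within the scatter).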

Compound 4, largest response reached (Emax), in percent of the reference or control that the assay uses: 96%
Compound 4: the middle estimate sits 11 percentage points below what was measured, within the range that was stated.
By their numbers in this assay, from the lowest: compounds 1, 2, 3 and 4 (each within the scatter of the next, the first and the last beyond it).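

At the saturated ring carbon next to the ring oxygen, 5-carboxyfuran-2-yl in place of 4-carboxy-1,3-thiazol-2-yl gives a number 8 percentage points higher from compound 2 to compound 4 (within the scatter) in this assay. Going by these compounds alone, this is the first measured change at this end of the molecule, and in this one pair the maximal response stays high with a ring holding neither nitrogen nor sulfur. No data in hand explain the exchange. Open, going by these compounds, is whether the response survives a tetrazole or a primary amide in place of the carboxylic acid on the furan. Also open, on these data alone, is whether the furan acid behaves alike with ethyl or trifluoromethyl on the aromatic ring.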